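A few compounds are considered here, and "the series" means these few. Any claim that something is new, unique, unknown or untested is made for them only; others in the source may bear on it.

Compound 1 `CC(C)CN1CCCC[C@H]1C(=O)Nc1cc(C(C)(C)C)on1` is the most soluble of the three measured compounds: in a physicochemical assay for solubility, read by HPLC, at pH 6.8 (a higher number here means a more soluble compound, a lower number a less soluble compound), compound 1 gives 32 ug/mL. Compound 2 `CC(C)(C)c1cc(NC(=O)[C@@H]2CCCCN2C(=O)c2ccccc2)no1` carries a benzoyl group on the ring amine nitrogen instead of the isobutyl, and in this assay compound 2 gives 0.9 ug/mL, the lowest of the two numbers measured, with a 36-fold lower number from compound 1 to compound 2 (1.55 log units; beyond the scatter). Compound 3 `CC(C)(C)c1cc(NC(=O)[C@@H]2CCCCN2C(=O)c2ccc(Cl)cc2)no1` adds a chloro to the benzoyl ring. For compound 3 this assay reports only a limit, < 0.1 ug/mL, that is, (the limit of < 0.1 ug/mL in this assay, at which 1 of the 3 values shown sits). The steps of an at least 320-fold lower number from compound 1 to compound 3 (2.50 log units; beyond the scatter) and an at least 9.0-fold lower number from compound 2 to compound 3 (0.95 log units; beyond the scatter) both point the same way.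

Compound 4 `CC(C)(C)c1cc(NC(=O)[C@@H]2CCCCN2C(=O)N2CC[S+]([O-])CC2)no1` differs from compound 2 in one place: a group of 7 heavy atoms (4 carbon, 1 nitrogen, 1 oxygen, 1 sulfur; one six-membered non-aromatic ring with 2 hetero atoms) in place of a group of 6 heavy atoms (6 carbon; one six-membered aromatic ring of carbon only), on a carbonyl carbon. Among the measured compounds shown here, no measured step swaps the phenyl for such a ring, so the bearing evidence is indirect: compound 1, which has no aromatic ring on the amide, gives 32 ug/mL, while compound 2 and compound 3 show that adding or extending the aromatic ring lowered solubility by a 36-fold lower number from compound 1 to compound 2 (1.55 log units; beyond the scatter) and an at least 9.0-fold lower number from compound 2 to compound 3 (0.95 log units; beyond the scatter). A rise beyond the scatter is therefore expected, about a 22-fold higher number from compound 2 to compound 4 (1.35 log units; beyond the scatter). For compound 4 the estimated solubility is 20 ug/mL, expected between 5 ug/mL and 80 ug/mL.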

Compound 4, solubility: 68 ug/mL
The estimate for compound 4 lay 3.4-fold (0.53 log units) below the measured number; the measured number falls inside the stated range.
By their numbers in this assay, from the lowest: compound 2; then compound 1; then compound 4. At a limit, below all of these: compound 3.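

Earlier steps on the ring amine nitrogen only lowered the number, whereas here, on a carbonyl carbon, replacing phenyl with the six-membered non-aromatic ring with 2 hetero atoms gives a 76-fold higher number from compound 2 to compound 4 (1.88 log units; beyond the scatter). Carrying a carbonyl on that nitrogen therefore does not by itself hold solubility low, as the carbonyl stays in place and the result is still a 2.1-fold higher number from compound 1 to compound 4 (0.33 log units; beyond the scatter), a modest step in this assay. There is also an at least 680-fold higher number from compound 3 to compound 4 (2.83 log units; beyond the scatter), but that step starts from a limit of the assay, not a number: the limit of < 0.1 ug/mL in this assay, at which 1 of the 4 values shown sits.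

From the compounds shown here alone, whether the rise goes with the sulfur and its oxygen or simply with the loss of the aromatic ring stays open, and a piperidine or a morpholine on that carbonyl carbon would separate the two. How a ring carrying an amine or a carboxylic acid would read in this assay is also left open.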